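Trading a Phenethyl Chain for a Dichlorophenyl Ring

The source may report more compounds than this note shows. Statements on the series, on what has been measured and on what is new or still open speak of the compounds shown alone.

Of the compounds shown here, three built on one shared core have been measured in an in vitro functional assay on RBL cells for antagonist activity at C-C chemokine receptor type 8 (Homo sapiens), read by FLIPR and calcium flux; on this read-out higher numbers stand for weaker inhibition and lower numbers for stronger inhibition. Compound 1 `COc1ccc2nccc(C3CN(C4CCN(Cc5cc6ccccc6o5)CC4)C(=O)O3)c2c1` gives 1260 nM, compound 2 `COc1ccc2nccc(C3CN(C4CCN(Cc5cc6ccccc6s5)CC4)C(=O)O3)c2c1` gives 794 nM, and compound 3 `COc1ccc2nccc(C3CN(C4CCN(CCCc5ccccc5)CC4)C(=O)O3)c2c1` gives 251 nM, the lowest of the three numbers, so it shows the strongest inhibition in this set. The step of a 1.6-fold lower number from compound 1 to compound 2 (0.20 log units; within the scatter) is small, whereas a 5.0-fold lower number from compound 1 to compound 3 (0.70 log units; beyond the scatter) and a 3.2-fold lower number from compound 2 to compound 3 (0.50 log units; beyond the scatter) both exceed the scatter.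

Compound 4 `COc1ccc2nccc(C3CN(C4CCN(Cc5ccc(Cl)c(Cl)c5)CC4)C(=O)O3)c2c1` has not yet been measured. Its change from compound 3 is 3,4-dichlorophenyl in place of phenethyl on a saturated chain carbon bound to an amine nitrogen in a ring. The two steps that reach compound 3 bear on this position: in each, a fused aromatic group sitting on the saturated chain carbon bound to the amine nitrogen in the ring was replaced by phenethyl, and the number fell. Compound 4 goes the other way, once more placing an aromatic ring directly on that chain carbon. Among the measured compounds shown here, a step toward a higher number, meaning weaker inhibition, is therefore expected in this assay, of a size comparable to those earlier steps, though a dichlorophenyl ring has no precedent here. Compound 4 is expected to give 630 nM, within a range from 200 nM to 2000 nM. The expected step is a 2.5-fold higher number from compound 3 to compound 4 (0.40 log units; beyond the scatter).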

Compound 4, half-maximal inhibitory concentration: 126 nM
Compound 4: middle estimate off by 5.0-fold (0.70 log units), on the high side, outside the stated range (below it).
By their numbers in this assay, from the lowest: compounds 4 and 3 (each within the scatter of the next); then compounds 2 and 1 (each within the scatter of the next).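

A ring placed directly on the saturated chain carbon bound to the amine nitrogen need not give a higher number in this assay than phenethyl does: the step here (a 2.0-fold lower number from compound 3 to compound 4 (0.30 log units; within the scatter)) leaves 3,4-dichlorophenyl and phenethyl indistinguishable. The higher numbers of compound 1 and compound 2 therefore cannot be put down simply to having an aromatic group directly on that carbon, and the identity of the group clearly matters, as the steps to the dichlorophenyl compound show (a 6.3-fold lower number from compound 2 to compound 4 (0.80 log units; beyond the scatter); a 10-fold lower number from compound 1 to compound 4 (1.00 log units; beyond the scatter)). Nothing measured here explains why these groups differ.

On these data alone, what the two chlorines contribute remains open, as does the role of chain length: a plain benzyl with no chlorine, and a 3,4-dichlorophenyl carried on a longer chain, would separate those two questions. Also open, as far as these compounds go, is how this position would respond to a group of a different kind, such as an amine or a carboxylic acid on the ring.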